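Pyrazolyl Amine in Place of Hydroxymethylethyl Amine on Compound 3

The source may hold more compounds than are shown below. What is called first, only, known or untested is meant among the compounds shown, and "the series" means these compounds.

In a functional assay on COLO 205 cells (Homo sapiens) for antiproliferative activity, read by luminescence, with a stated time of 72 h (on this read-out higher numbers stand for weaker inhibition and lower numbers for stronger inhibition), compound 1 `Cc1cnc(Nc2ccnn2C)nc1N1Cc2cn(C(CO)c3cccc(Cl)c3)nc2C1` gives 248 nM and compound 2 `Cc1cnc(Nc2ccnn2C)nc1-c1cc2n(c1)C(=O)N([C@H](CO)c1cccc(Cl)c1)CC2` gives 77.1 nM. Compound 3 `C[C@H](CO)Nc1ncc(Cl)c(-c2cc3n(c2)C(=O)N([C@H](CO)c2cccc(Cl)c2)C3)n1` has no single number in this assay; it was reported as "not active" (no number reported). Compound 4 `Cn1nccc1Nc1ncc(Cl)c(-c2cc3n(c2)C(=O)N([C@H](CO)c2cccc(Cl)c2)C3)n1` differs from compound 3 in one place: 1-methyl-1H-pyrazol-5-yl in place of 1-(hydroxymethyl)ethyl on a nitrogen on an aromatic ring. Within the data shown here, no measured pair shows this change, so no step size can be read from the data. Compound 2 carries the same 1-methyl-1H-pyrazol-5-yl on a nitrogen on an aromatic ring and gives 77.1 nM, whereas compound 3 carries 1-(hydroxymethyl)ethyl there and is not active, so the step is expected to move toward stronger inhibition, by more than the scatter. Compound 4 is therefore estimated at 150 nM, with a range from 40 nM to 600 nM.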

Compound 4, half-maximal inhibitory concentration: 31.9 nM
Compound 4: the middle estimate sits 4.7-fold (0.67 log units) above what was measured; the whole stated range lies above it.
By their numbers in this assay, from the lowest: compound 4; then compound 2; then compound 1.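

Among these compounds, compound 3 has no number in this assay, and no step from it to compound 4 can be read. The compounds shown leave open how large the change from 1-(hydroxymethyl)ethyl to 1-methyl-1H-pyrazol-5-yl is, and no measurement here bears on an explanation.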